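One Measured Value and a New Group to Test

A few compounds are considered here, and "the series" means these few. Any claim that something is new, unique, unknown or untested is made for them only; others in the source may bear on it.

Compound 1 `O=C(N/N=C/c1cccc(Cl)c1Cl)Nc1ccc(Oc2ccnc3[nH]ccc23)c(F)c1` and compound 2 `O=C(N/N=C/c1cc(Br)c(O)c(Br)c1)Nc1ccc(Oc2ccnc3[nH]ccc23)c(F)c1` share a core and differ in the group on a carbon with a double bond to nitrogen. In a functional assay on HepG2 cells (Homo sapiens) for antiproliferative activity, read by MTT assay, with a stated time of 72 h (on this read-out higher numbers stand for weaker inhibition and lower numbers for stronger inhibition), compound 1 is reported as "not active" (no number reported) with no number attached. Among the measured compounds shown here, compound 2 gives 6520 nM and this is the only number available, so it has no measured neighbour to be ranked against.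

Compound 3 `CN(C)CCn1cccc1/C=N/NC(=O)Nc1ccc(Oc2ccnc3[nH]ccc23)c(F)c1` keeps the same core. The change is 1-(2-(dimethylamino)ethyl)-1H-pyrrol-2-yl in place of 3,5-dibromo-4-hydroxyphenyl on a carbon with a double bond to nitrogen and the rest of the structure stays as it is.

Nothing measured here shows how far a new group at this place moves the number, so compound 2 at 6520 nM is the only anchor. On that basis the expected step of a 1.3-fold lower number from compound 2 to compound 3 (0.12 log units; within the scatter) stays within the usual scatter in this assay with no clear direction, though a result without a number, as for compound 1, remains possible. Compound 3 is estimated at 5000 nM within an expected range of 1000 nM to 25000 nM on this read-out.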

Compound 3, half-maximal inhibitory concentration: 8980 nM
Compound 3: middle estimate off by 1.8-fold (0.25 log units), on the low side, and the stated range covers the measured number.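

In this assay, among the compounds shown here, putting 1-(2-(dimethylamino)ethyl)-1H-pyrrol-2-yl in place of 3,5-dibromo-4-hydroxyphenyl on a carbon with a double bond to nitrogen gives a 1.4-fold higher number from compound 2 to compound 3 (0.14 log units; within the scatter), the first measured step at this position. It shows that two quite different groups can sit here and give numbers that cannot be told apart: one has a six-membered aromatic ring of carbon only, with bromine and a hydrogen-bond donor, and the other has a five-membered aromatic ring with 1 hetero atom, a dimethylamino chain and 0 hydrogen-bond donors. No supporting measurement is available to account for this result.

The compounds shown leave open which part of the entering group matters, since the pyrrole ring and its 2-(dimethylamino)ethyl chain arrive together, and a bare 1H-pyrrol-2-yl, or the same ring with a morpholine at the end of the chain, would separate the two. As far as these compounds go, it also remains open whether a group such as a carboxylic acid on the phenyl ring would stay close to these two numbers or would end without a number, like compound 1 at "not active" (no number reported), in this assay.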